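A few compounds are considered here, and "the series" means these few. Any claim that something is new, unique, unknown or untested is made for them only; others in the source may bear on it.

Of the compounds shown here, three sharing one core have been measured in a functional assay on THP-1 cells (Homo sapiens) for cytotoxicity, read by MTT assay, with a stated time of 24 h; on this read-out lower numbers stand for stronger inhibition and higher numbers for weaker inhibition. Compound 1 (`CN1C/C(=C\c2ccc(C(F)(F)F)cc2)C(=O)/C(=C/c2ccccc2F)C1`) gives 5930 nM, compound 2 (`COc1cc(/C=C2\CN(C)C/C(=C\c3cccc([N+](=O)[O-])c3)C2=O)cc(OC)c1`) gives 1770 nM, and compound 3 (`CN1C/C(=C\c2ccc(F)cc2)C(=O)/C(=C/c2cccc([N+](=O)[O-])c2)C1`) gives 7160 nM. Compound 3 thus stands level with compound 1, within the scatter, while compound 2 reads lower than compound 3 by a margin beyond the scatter.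

Compound 4 (`CN1C/C(=C\c2cccc(Br)c2)C(=O)/C(=C/c2cccc([N+](=O)[O-])c2)C1`) has yet to be measured. It differs from compound 3 in one place: 3-bromophenyl in place of 4-fluorophenyl on a double-bonded chain carbon bound to a double-bonded ring carbon. Here 3-bromophenyl stands in place of 4-fluorophenyl on a double-bonded chain carbon bound to a double-bonded ring carbon.

For the measured compounds named here, no measured pair differs in a single place, so the data offer no direct precedent for this exchange. In this assay a step within the scatter is expected, if anything toward a lower number, since compound 2 at 1770 nM shows that lower numbers occur in this small set. The expected step is a 1.6-fold lower number from compound 3 to compound 4 (0.20 log units; within the scatter). For compound 4 the estimated value is 4500 nM, with an expected range from 2000 nM to 10000 nM.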

Compound 4, half-maximal inhibitory concentration: 4030 nM
For compound 4 the middle estimate is 1.1-fold (0.05 log units) above the measured one; measured number inside the range.
By their numbers in this assay, from the lowest: compound 2; then compounds 4, 1 and 3 (each within the scatter of the next).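

For the compounds shown here, the first single-place step in this set reads, in this assay, as a 1.8-fold lower number from compound 3 to compound 4 (0.25 log units; within the scatter), so compound 3 and compound 4 stand level. At this place on a double-bonded chain carbon bound to a double-bonded ring carbon, then, 4-fluorophenyl and 3-bromophenyl cannot be told apart by this read-out, although the exchange alters both the halogen and its place on the phenyl ring. No measurement at hand bears on why the two compounds read alike.

The compounds shown do not separate the halogen from its place on the phenyl ring, as 3-fluorophenyl or 4-bromophenyl at this position would. They also leave open whether a phenyl ring carrying an amine or a carboxylic acid here would give a step beyond the scatter.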